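This account rests on a few compounds, and the source may have more. Where it says the series, first, only, none or still open, it means among the compounds named here.

In a functional assay on HeLa cells (Homo sapiens) for cytotoxicity, read by MTT assay, with a stated time of 72 h (on this read-out higher numbers stand for weaker inhibition and lower numbers for stronger inhibition), compound 1 `Cc1ccc2oc(CSc3nnc(C)s3)cc(=O)c2c1` gives only a limit, > 25000 nM. Compound 2 `Cc1ccc2oc(CSc3nnc(N)s3)cc(=O)c2c1` likewise gives only a limit, > 25000 nM. Compound 3 `Nc1nnc(SCc2coc3ccccc3c2=O)s1` also gives only a limit, > 25000 nM.

From compound 2 to compound 1 the change is methyl in place of amino on an aromatic carbon. The step that the two limits leave unreadable from compound 2 to compound 1 stays unreadable because both values sit at the limit of > 25000 nM in this assay, at which 3 of the 3 values shown sit. How the cores of compound 2 and compound 3 differ is not broken down here. Compound 4 `Cc1nnc(SCc2coc3ccccc3c2=O)s1`, not yet measured, differs from compound 3 by methyl in place of amino on an aromatic carbon, the same change as from compound 2 to compound 1. Since every measured value is a limit, the step that the limit leaves unreadable from compound 3 to compound 4 is estimated to leave compound 4 where compound 3 stands. Compound 4 is expected near 30000 nM in this assay, between 15000 nM and 100000 nM, most likely again as a limit.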

Compound 4, half-maximal inhibitory concentration: 2300 nM
Estimate against measurement, compound 4: 13-fold (1.12 log units) above; measured number outside the range, below it.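

In this assay, methyl in place of amino on an aromatic carbon gives an at least 10-fold lower number from compound 3 to compound 4 (1.03 log units; beyond the scatter), so on the core of compound 3 the change brings a readable number. The same change from compound 2 to compound 1 cannot be read, as neither compound gets past the limit: the limit of > 25000 nM in this assay, at which 3 of the 4 values shown sit. The effect seen on one core therefore does not reach a readable number on the other, but its size there and the reason for the difference between the cores remain unknown.

The compounds shown leave open whether an ethyl group or a longer chain in place of the methyl of compound 4 would keep its lower number. They also leave open what a dimethylamine group would do at that place.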